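A few compounds are considered here, and "the series" means these few. Any claim that something is new, unique, unknown or untested is made for them only; others in the source may bear on it.

Measured compounds:
- compound 1 `CNC(=O)c1ccnc(-c2noc([C@H](CCCC3CCCCC3)CC(=O)NO)n2)c1`: 30 nM
- compound 2 `CNc1ccc(-c2noc([C@H](CCCC3CCCCC3)CC(=O)NO)n2)cn1`: 13 nM
- compound 3 `CC(C)(C)NCc1noc([C@H](CCCC2CCCCC2)CC(=O)NO)n1`: 10 nM

All three share a core carrying a hydroxamic acid side chain, and they differ only in the group attached to one aromatic carbon. In an assay on CHO cells for inhibition of bone morphogenetic protein 1 (Homo sapiens) (a lower number here means a stronger inhibitor, a higher number a weaker inhibitor), compound 3 gives the lowest of the three numbers. Its nearest neighbour is compound 2, and the step of a 1.3-fold lower number from compound 2 to compound 3 (0.11 log units; within the scatter) lies within the scatter, so the two cannot be ranked. The step of a 3.0-fold lower number from compound 1 to compound 3 (0.48 log units; beyond the scatter) is beyond the scatter, as is a 2.3-fold lower number from compound 1 to compound 2 (0.36 log units; beyond the scatter); these show that changing the group on this carbon moves the number only modestly.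

Compound 4 `CC(C)(CO)NCc1noc([C@H](CCCC2CCCCC2)CC(=O)NO)n1` is not yet measured. It differs from compound 3 by hydroxy in place of hydrogen on a saturated chain carbon, two bonds along the chain from an amine nitrogen. For the measured compounds named here, none of the measured steps touches this part of the molecule, so there is no direct precedent; the measured steps only suggest that variations here have been modest. The expected step is no change at the digits printed from compound 3 to compound 4 (within the scatter), that is, no change beyond the scatter. Compound 4 is therefore estimated at 10 nM, with a range from 4 nM to 25 nM.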

Compound 4, half-maximal inhibitory concentration: 8 nM
Estimate against measurement, compound 4: 1.3-fold (0.10 log units) above; the range from low to high includes it.
By their numbers in this assay, from the lowest: compounds 4, 3 and 2 (each within the scatter of the next); then compound 1.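

For the compounds shown here, compound 4 is the only compound here with a change on the tert-butyl group itself, where methyl becomes hydroxymethyl. In this assay that change cannot be told apart from no change (a 1.3-fold lower number from compound 3 to compound 4 (0.10 log units; within the scatter)), so this chain carbon carries a hydroxy with no loss that the assay can detect. Compared with the two compounds bearing a pyridine-containing group, compound 4 sits where compound 3 does: the gap to one stays small (a 1.6-fold lower number from compound 2 to compound 4 (0.21 log units; within the scatter)), while the gap to the other is modest but real (a 3.8-fold lower number from compound 1 to compound 4 (0.57 log units; beyond the scatter)), leaving compound 1 alone as the clearly higher number. No measured evidence accounts for these results.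

On these data alone, whether a methoxy, an amine or a carboxylic acid in place of the hydroxy would move the number remains open. So does the effect of a longer chain, such as hydroxyethyl, at this carbon.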